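Series notes: methyl to cyclohexyl on the ring-bound nitrogen

The source may report more compounds than this note shows. Statements on the series, on what has been measured and on what is new or still open speak of the compounds shown alone.

In a physicochemical assay for lipophilicity (a higher number here means a more lipophilic compound, a lower number a more polar compound), compound 1 `CCN(C1=NCCN1)c1c(Br)cccc1Br` gives -1.01. Within the data shown here, its only measured neighbour, compound 2 `C=CCN(C1=NCCN1)c1c(Br)cccc1Br`, gives -0.75 in this assay; the two numbers lie within the scatter of each other, as a number 0.26 log units higher from compound 1 to compound 2 (within the scatter) shows. Compound 3 `Brc1cccc(Br)c1N(CC1CCCCC1)C1=NCCN1` is not yet measured in this assay. It differs from compound 1 by cyclohexyl in place of methyl on a saturated chain carbon bound to a nitrogen on an aromatic ring. Among the measured compounds shown here, the one step that bears on the same place, a number 0.26 log units higher from compound 1 to compound 2 (within the scatter), was small. The present change is larger in what it brings in, so a clear rise in this assay is expected, estimated as a number 2.01 log units higher from compound 1 to compound 3 (beyond the scatter). Compound 3 is therefore expected to give 1, with a range from 0.3 to 1.7.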

Compound 3, distribution coefficient: 0.27
For compound 3 the middle estimate is 0.73 log units above the measured one; measured number outside the range, below it.
By their numbers in this assay, from the lowest: compounds 1 and 2 (each within the scatter of the next); then compound 3.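

Among these compounds, both a number 1.28 log units higher from compound 1 to compound 3 (beyond the scatter) for cyclohexyl in place of methyl and a number 1.02 log units higher from compound 2 to compound 3 (beyond the scatter) for cyclohexyl in place of vinyl lie beyond the scatter in this assay and are the first steps of that size at this place. Compound 3 therefore stands clear of compounds 1 and 2, which the earlier step could not separate. Nothing in hand accounts for the size of these steps.

A hexyl chain at this place would tell whether the step follows the ring or only the added carbons. Going by these compounds, how an amine on the same chain would read in this assay also stays open.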